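Cytotoxicity notes on a cyclic sulfonate ether series

The source may hold more compounds than are shown below. What is called first, only, known or untested is meant among the compounds shown, and "the series" means these compounds.

Compound 1 `CCC1(Cc2ccccc2)OS(=O)(=O)C=C1OC(c1ccccc1)c1ccccc1` is the reference here. In an ADME assay on HEL cells (Homo sapiens) for cytotoxicity, with a stated time of 3 days (on this read-out lower numbers stand for higher toxicity in this test and higher numbers for lower toxicity in this test), compound 1 gives only a limit of the test, > 200000 nM, which places it at the limit of > 200000 nM in this assay, at which 1 of the 2 values shown sits. Compound 2 `CCC1(Cc2ccccc2)OS(=O)(=O)C=C1OCc1ccc(Cl)c(Cl)c1` gives 36700 nM in this assay. Compound 3 `CCC1(Cc2ccccc2)OS(=O)(=O)C=C1OCc1ccccc1` is not yet measured; it differs from compound 1 by hydrogen in place of phenyl on a saturated chain carbon bound to an aromatic carbon and an oxygen on an unsaturated carbon. Among the measured compounds shown here, no measured pair shows this change, so the expected step from compound 1 to compound 3 is a guess of an at least 1.6-fold lower number from compound 1 to compound 3 (0.22 log units; that floor lies within the scatter), towards somewhat higher toxicity, which may still end at the limit. Compound 3 is expected to give about 120000 nM in this assay, within 40000 nM to 200000 nM.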

Compound 3, half-maximal cytotoxic concentration: 200000 nM
Beside the measured number, compound 3's estimate is 1.7-fold (0.22 log units) below it; the measured number falls inside the stated range.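

In this assay, phenyl in place of 3,4-dichlorophenyl on a saturated chain carbon bound to an oxygen on an unsaturated carbon gives a 5.4-fold higher number from compound 2 to compound 3 (0.74 log units; beyond the scatter), so the chlorines on this group go with higher toxicity in this test. The other step, hydrogen in place of phenyl on a saturated chain carbon bound to an aromatic carbon and an oxygen on an unsaturated carbon, gives a number no higher from compound 1 to compound 3 (the limit leaves the size open). Its size cannot be read because compound 1 stands at a limit of the test: the limit of > 200000 nM in this assay, at which 1 of the 3 values shown sits.

On these data alone, whether a single chlorine would carry the step to compound 3 stays open. So does how a methoxy group or an amine on the phenyl would read.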